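Ethynyl for Acetoxymethyl: Expected Cytotoxicity of Compound 4

The compounds below may be only part of what the source reports. "The series", "measured", "known", "first", "only" and "open" are said of these compounds alone.

Compound 1 `CC(=O)OCCOCN1C(=O)c2ccccc2NS1(=O)=O` gives > 200 ug/mL in a functional assay on HEL cells (Homo sapiens); on this read-out lower numbers stand for higher toxicity in this test and higher numbers for lower toxicity in this test; this is a limit of the test and not a number.
Compound 2 `CC(=O)OCCOCN1c2ccccc2C(=O)N(Cc2ccccc2)S1(=O)=O` gives 100 ug/mL in this assay.
Compound 3 `C#CCOCN1c2ccccc2C(=O)N(Cc2ccccc2)S1(=O)=O` gives > 50 ug/mL in this assay; this too is a limit of the test and not a number.

The difference between the core of compound 1 and the core of compound 2 is not broken down here. Compound 2 and compound 3 differ by ethynyl in place of acetoxymethyl on a saturated chain carbon bound to an oxygen on a saturated carbon, and the step that the limit leaves unreadable from compound 2 to compound 3 cannot be read because of the limit of > 50 ug/mL in this assay, at which 1 of the 3 values shown sits. Compound 4 `C#CCOCN1C(=O)c2ccccc2NS1(=O)=O` is unmeasured and stands to compound 1 as compound 3 stands to compound 2: the change is ethynyl in place of acetoxymethyl on a saturated chain carbon bound to an oxygen on a saturated carbon, the same change at the same place. For compound 1 only the limit of > 200 ug/mL in this assay, at which 1 of the 3 values shown sits, is known, so no measured size carries over. Compound 4 is expected to show a step of a number no higher from compound 1 to compound 4 (the limit leaves the size open) in this assay. Compound 4 is estimated at 200 ug/mL, between 80 ug/mL and 500 ug/mL.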

Compound 4, half-maximal cytotoxic concentration: 169 ug/mL
For compound 4 the middle estimate is 1.2-fold (0.07 log units) above the measured one; the range from low to high includes it.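

In this assay ethynyl in place of acetoxymethyl gives an at least 1.1-fold lower number from compound 1 to compound 4 (0.07 log units; that floor lies within the scatter) on the core of compound 1, so this floor alone establishes no real change. Compound 1 gives > 200 ug/mL in this assay as a limit of the test and not a number, which leaves the true size of the step open. The same change from compound 2 to compound 3 cannot be read, so the two cores cannot be compared, and nothing shows whether the change carries over with the same size.

The compounds shown leave open how an amine, a carboxylic acid or a longer chain would read at this place. They also leave open how the change would read on any further core.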